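A few compounds are considered here, and "the series" means these few. Any claim that something is new, unique, unknown or untested is made for them only; others in the source may bear on it.

Within the data shown here, compound 1 `CCCOC(=O)Nc1ccc([Se]C#N)cc1` is one of two compounds measured so far in a functional assay on MCF7 cells (Homo sapiens) for cytotoxicity, read by MTT assay, with a stated time of 72 h; a higher number here means a weaker inhibitor of growth, a lower number a stronger inhibitor of growth. In this assay compound 1 gives 8000 nM, the highest of the two numbers. Its nearest neighbour is compound 2 `Cc1ccc(OC(=O)Nc2ccc([Se][Se]c3ccc(NC(=O)Oc4ccc(C)cc4)cc3)cc2)cc1`, which in this assay gives 6900 nM; the two values lie within the scatter of each other, so nothing separates them. Compound 3 `N#C[Se]c1ccc(NC(=O)OCc2ccccc2)cc1` has not yet been measured. It differs from compound 1 in one place: phenyl in place of ethyl on a saturated chain carbon bound to an oxygen next to a carbonyl group. Among the measured compounds shown here, no measured pair shows what such a swap does in this assay, so compound 1 is the only anchor, with its value of 8000 nM. With only this to go on, a step of a 1.2-fold lower number from compound 1 to compound 3 (0.09 log units; within the scatter) is expected, meaning no change beyond the scatter. For compound 3 the estimate in this assay is 6500 nM, with a likely range from 2500 nM to 17000 nM.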

Compound 3, concentration for 50% growth inhibition: 8700 nM
Beside the measured number, compound 3's estimate is 1.3-fold (0.13 log units) below it; low and high end bracket the measured number.
By their numbers in this assay, from the lowest: compounds 2, 1 and 3 (each within the scatter of the next).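

In this assay, phenyl in place of ethyl on a saturated chain carbon bound to an oxygen next to a carbonyl group gives a 1.1-fold higher number from compound 1 to compound 3 (0.04 log units; within the scatter). Among these compounds, this is the first measured pair at this place, and it shows that a six-membered aromatic ring of carbon only can stand where a two-carbon ethyl stood without moving the number beyond the usual scatter. Nothing measured here explains this result.

On these data alone, whether an amine, a carboxylic acid or a longer chain such as butyl at this place would move the number beyond the scatter remains open. Also open, as far as these compounds go, is whether the same swap of ethyl for phenyl would give so small a step on a different core, as this single pair speaks only for the core of compound 1.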